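Naphthoquinone series: furan to thiophene on the aryl ether

The source may hold more compounds than are shown below. What is called first, only, known or untested is meant among the compounds shown, and "the series" means these compounds.

Of the compounds shown here, three have been measured in a functional assay on KB cells (Homo sapiens) for cytotoxicity; on this read-out lower numbers stand for stronger inhibition and higher numbers for weaker inhibition. Compound 1 `CCOC1=CC(=O)c2ccccc2C1=O` gives 16900 nM. Compound 2 `O=C(Oc1ccc2c(c1)C(=O)C=CC2=O)c1ccccc1` gives 12100 nM. Compound 3 `O=C1C=CC(=O)c2c(Oc3ccco3)cccc21` gives 13400 nM, and all three numbers fall within the usual scatter of one another, so none of the three can be set apart from the others on these data; compound 3 sits within the scatter of compound 2 and of compound 1 alike.

Compound 4 `O=C1C=CC(=O)c2c(Oc3cccs3)cccc21` has not yet been measured in this assay. It differs from compound 3 in one place: thiophen-2-yl in place of furan-2-yl on an oxygen on an aromatic ring. Going by the values given here, no comparable pair of measured compounds exists in the set, so the size of this step can only be estimated, not read from the data.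

With compound 3 at 13400 nM as the anchor, compound 4 is expected to stay close to that number. The step from compound 3 to compound 4 is estimated at a 1.0-fold lower number from compound 3 to compound 4 (0.01 log units; within the scatter), which is taken to be no larger than the scatter, in no particular direction. Compound 4 is therefore estimated at 13000 nM in this assay, with a range from 6000 nM to 28000 nM that allows for the scatter and for the unknown effect of the change.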

Compound 4, half-maximal inhibitory concentration: 6230 nM
Beside the measured number, compound 4's estimate is 2.1-fold (0.32 log units) above it; measured number inside the range.
By their numbers in this assay, from the lowest: compounds 4, 2, 3 and 1 (each within the scatter of the next, the first and the last beyond it).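

Going by these compounds alone, the exchange of furan-2-yl for thiophen-2-yl on an oxygen on an aromatic ring gives the first step that can be read between two compounds differing in one place: in this assay it is a 2.2-fold lower number from compound 3 to compound 4 (0.33 log units; beyond the scatter) and thus a modest change, but one that clears the scatter. The two groups count the same heavy atoms, hydrogen-bond donors and acceptors and carry no net charge, differing only in oxygen against sulfur as the ring hetero atom, so this position does register a change as small as one atom in the ring. Nothing at hand bears on why the number moves with this exchange.

Still open, on these data alone, is whether the step holds at this size on the cores of compound 1 and compound 2, since it rests on a single pair. Also open, as far as these compounds go, is how the position responds to groups of a different kind on the same oxygen, such as phenyl, pyridin-2-yl or a longer alkyl chain ending in an amine, and whether any of these moves the number further than thiophen-2-yl does.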